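The source may report more compounds than this note shows. Statements on the series, on what has been measured and on what is new or still open speak of the compounds shown alone.

Measured compounds:
compound 1 `CNS(=O)(=O)c1ccc(-c2cnc(N)c(-c3ccc(OC)nc3)c2)cc1` — 12.5 ug/mL
compound 2 `COc1ccc(-c2cc(-c3ccc(-n4cncn4)cc3)cnc2N)cn1` — 6.3 ug/mL
compound 3 `COc1ccc(-c2cc(-c3ccc(-n4cccn4)cc3)cnc2N)cn1` — 3.1 ug/mL

In a physicochemical assay for solubility, read by nephelometry, in phosphate buffer, measured as kinetic solubility, at pH 6.5 (on this read-out lower numbers stand for lower solubility and higher numbers for higher solubility), compound 3 stands lowest of the three: the step of a 4.0-fold lower number from compound 1 to compound 3 (0.61 log units; beyond the scatter) is the largest gap in the set, and the step of a 2.0-fold lower number from compound 2 to compound 3 (0.31 log units; beyond the scatter) separates it from its nearest neighbour, while the step of a 2.0-fold lower number from compound 1 to compound 2 (0.30 log units; within the scatter) between the other two does not exceed the scatter.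

The next compound, compound 4 `COc1ccc(-c2cc(-c3ccc(C(N)=O)cc3)cnc2N)cn1`, differs from compound 3 in one place: carbamoyl in place of 1H-pyrazol-1-yl on an aromatic carbon. Two of the measured steps bear on this change, since both replace a group at the same position on the shared core. The step of a 4.0-fold lower number from compound 1 to compound 3 (0.61 log units; beyond the scatter) shows that exchanging the five-membered ring for a non-ring substituent at this position has moved solubility by a modest, measurable amount, and the step of a 2.0-fold lower number from compound 2 to compound 3 (0.31 log units; beyond the scatter) shows the pyrazolyl analogue sits at the low end. A step in the upward direction, of a size comparable to the step from compound 1 to compound 3, is therefore expected: a 3.2-fold higher number from compound 3 to compound 4 (0.51 log units; beyond the scatter). Compound 4 is estimated at 10 ug/mL in this assay, with a range from 4 ug/mL to 25 ug/mL.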

Compound 4, solubility: 12.5 ug/mL
The estimate for compound 4 lay 1.3-fold (0.10 log units) below the measured number; low and high end bracket the measured number.
By their numbers in this assay, from the lowest: compound 3; then compounds 2, 1 and 4 (each within the scatter of the next).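

With carbamoyl on this aromatic carbon, para to a large group, this assay gives a 4.0-fold higher number from compound 3 to compound 4 (0.61 log units; beyond the scatter), so a second non-ring group now stands clear of 1H-pyrazol-1-yl, and compound 3 is set apart from all three other compounds. Carbamoyl cannot be told apart from the other two groups: a 2.0-fold higher number from compound 2 to compound 4 (0.30 log units; within the scatter) and no change at the digits printed from compound 1 to compound 4 (within the scatter), so methylsulfamoyl can give way to a group of 3 heavy atoms without a readable change, and ring against non-ring does not sort the series, as compound 2, with its 1H-1,2,4-triazol-1-yl ring, lies within the scatter of both compound 1 and compound 4. No measurement shown accounts for these steps.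

From the compounds shown here alone, how an amine or a carboxylic acid at this place would read in this assay remains open. So does whether a methyl or longer chain on the carbamoyl nitrogen would keep compound 4's reading.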